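The compounds below may be only part of what the source reports. "The series", "measured", "known", "first", "only" and "open" are said of these compounds alone.

Working notes on the series in an in vitro ADME assay on microsomes from liver (Mus musculus) for pharmacokinetics, read by LC-MS, with a stated time of 10 min, tested at 1 uM; on this read-out lower numbers stand for slow clearance and higher numbers for fast clearance. Compound 1 `CC(C)c1ccc(NC(=O)[C@H]2CN(C)C[C@@H]2c2ccc(/C=C/C(=O)Nc3ccccc3N)cc2)cc1` gives 54 mL/min/kg, compound 2 `CN1C[C@H](C(=O)Nc2ccc(C3CC3)cc2)[C@@H](c2ccc(/C=C/C(=O)Nc3ccccc3N)cc2)C1` gives 60 mL/min/kg, and compound 3 `Cc1cccc(NC(=O)[C@H]2CN(C)C[C@@H]2c2ccc(/C=C/C(=O)Nc3ccccc3N)cc2)c1` gives 74 mL/min/kg. Compound 3 therefore stands within the scatter of both other compounds. Compound 4 `CN1C[C@H](C(=O)Nc2ccccc2F)[C@@H](c2ccc(/C=C/C(=O)Nc3ccccc3N)cc2)C1` has 2-fluorophenyl in place of 3-methylphenyl on an amide-type nitrogen. Three measured steps alter the group at this place: a 1.1-fold higher number from compound 1 to compound 2 (0.05 log units; within the scatter), a 1.4-fold higher number from compound 1 to compound 3 (0.14 log units; within the scatter) and a 1.2-fold higher number from compound 2 to compound 3 (0.09 log units; within the scatter). Going by the values given here, all three stay within the scatter, although no measured compound carries 2-fluorophenyl. No change beyond the scatter is therefore expected, and the estimated step is a 1.2-fold lower number from compound 3 to compound 4 (0.09 log units; within the scatter). For compound 4, the expected clearance is 60 mL/min/kg, with an estimated range of 35 mL/min/kg to 95 mL/min/kg.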

Compound 4, clearance: 67 mL/min/kg
Beside the measured number, compound 4's estimate is 1.1-fold (0.05 log units) below it; the measured number falls inside the stated range.
By their numbers in this assay, from the lowest: compounds 1, 2, 4 and 3 (each within the scatter of the next).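

In this assay the amide-type nitrogen now tolerates a fluorine-bearing aryl group as well as the three carbon-only ones, with every new step within the scatter (a 1.1-fold lower number from compound 3 to compound 4 (0.04 log units; within the scatter)) (a 1.1-fold higher number from compound 2 to compound 4 (0.05 log units; within the scatter)) (a 1.2-fold higher number from compound 1 to compound 4 (0.09 log units; within the scatter)). Clearance at this place has thus not separated any of the four aryl groups. Nothing at hand explains this flat response. As far as these compounds go, whether a phenyl group carrying an amine or a carboxylic acid, or a longer alkyl chain in place of the aryl group, would move clearance beyond the scatter stays open. Changes elsewhere in the shared core also remain untested here.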